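A few compounds are considered here, and "the series" means these few. Any claim that something is new, unique, unknown or untested is made for them only; others in the source may bear on it.

Two compounds of this series have numbers in a functional assay on trachea for agonist activity at cysteinyl leukotriene receptor (Homo sapiens); on this read-out lower numbers stand for stronger inhibition and higher numbers for weaker inhibition. Compound 1 `COc1cc(C(=O)NS(=O)(=O)c2ccccc2C)ccc1Cc1cn(C)c2ccc(C(=O)NCC3CCCC3)cc12` gives 4.28 nM and stands with the highest of the two numbers; compound 2 `COc1cc(C(=O)NS(=O)(=O)c2ccccc2C)ccc1Cn1ccc2ccc(NC(=O)CC3CCCC3)cc21` gives 0.106 nM, a lower number by a gap beyond the scatter. For the measured compounds named here, compound 2 differs from compound 1 in more than one place, so the two values show only that the pair spans a wide range, not what any single change does. Compound 3 `COc1cc(C(=O)NS(=O)(=O)c2ccccc2C)ccc1Cc1cn(C)c2ccc(NC(=O)CC3CCCC3)cc12` is an unmeasured rearrangement of compound 1 with the same atoms joined differently: ((cyclopentylmethyl)carbonyl)amino in place of (cyclopentylmethyl)carbamoyl on an aromatic carbon. Going by the values given here, the entering group is the one carried by compound 2. Among the compounds with values here, no single-change step of this kind has been measured. The step of a 7.1-fold lower number from compound 1 to compound 3 (0.85 log units; beyond the scatter) is expected to be a lowering beyond the scatter, because compound 2 with the same entering group gives 0.106 nM. Compound 3 is expected to give 0.6 nM in this assay, within 0.12 nM to 3 nM.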

Compound 3, antagonist equilibrium constant: 24.5 nM
Estimate against measurement, compound 3: 41-fold (1.61 log units) below; measured number outside the range, above it.
By their numbers in this assay, from the lowest: compound 2; then compound 1; then compound 3.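

In this assay, for the compounds shown here, ((cyclopentylmethyl)carbonyl)amino in place of (cyclopentylmethyl)carbamoyl gives a 5.7-fold higher number from compound 1 to compound 3 (0.76 log units; beyond the scatter), the first single-change step. Both groups hold the same atoms, so how they are joined at this aromatic carbon alone moves the number, and on the core of compound 1 the entering group does not bring a lower number. Nothing at hand accounts for the direction or size of this step.

Going by these compounds alone, no single-change step links compound 2 to either of the other compounds, so it remains open which of its differences goes with its low number. Also open, on these data alone, is how a urea or sulfonamide linkage, or a longer chain in place of cyclopentylmethyl, would read at this position.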